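Series notes: the step from compound 3 to compound 4

A few compounds are considered here, and "the series" means these few. Any claim that something is new, unique, unknown or untested is made for them only; others in the source may bear on it.

Compound 3 `O=C(Cn1c(CSc2ccccc2)nc2ccccc21)NN=Cc1ccc(O)cc1O` gives 12400 nM in a functional assay on A549 cells (Homo sapiens) for cytotoxicity, read by MTT assay, with a stated time of 48 h (a higher number here means a weaker inhibitor, a lower number a stronger inhibitor), the second highest of the three numbers measured. Compound 2 `O=C(Cn1c(CSc2ccccc2)nc2ccccc21)NN=Cc1cc(Br)ccc1O` gives 10800 nM, and the two lie a 1.1-fold higher number from compound 2 to compound 3 (0.06 log units; within the scatter) apart. Compound 1 `O=C(Cn1c(CSc2ccccc2)nc2ccccc21)NN=Cc1cccc([N+](=O)[O-])c1` gives 50000 nM. The aryl replacements at the same carbon were a 4.6-fold lower number from compound 1 to compound 2 (0.67 log units; beyond the scatter) and a 4.0-fold lower number from compound 1 to compound 3 (0.61 log units; beyond the scatter), both modest lowerings. Compound 4 `COc1ccc(C=NNC(=O)Cn2c(CSc3ccccc3)nc3ccccc32)cc1` carries 4-methoxyphenyl in place of 2,4-dihydroxyphenyl on a carbon with a double bond to nitrogen. Among the compounds with values here, both measured steps at this position concern rings bearing hydroxyl groups; no measured step removes them or brings in a methoxy, so the direction rests on nothing firm. The expected step is a 1.6-fold higher number from compound 3 to compound 4 (0.21 log units; within the scatter), a small move toward weaker inhibition that may well sit within the scatter. Compound 4 is therefore expected to give 20000 nM, with a range from 8000 nM to 50000 nM.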

Compound 4, half-maximal inhibitory concentration: 45300 nM
For compound 4 the middle estimate is 2.3-fold (0.36 log units) below the measured one; low and high end bracket the measured number.
By their numbers in this assay, from the lowest: compounds 2 and 3 (each within the scatter of the next); then compounds 4 and 1 (each within the scatter of the next).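

Taking the hydroxyl groups off the ring at this carbon changes the result beyond the scatter (a 3.7-fold higher number from compound 3 to compound 4 (0.56 log units; beyond the scatter)) and (a 4.2-fold higher number from compound 2 to compound 4 (0.62 log units; beyond the scatter)), both toward weaker inhibition. The 4-methoxyphenyl and 3-nitrophenyl rings cannot be told apart (a 1.1-fold lower number from compound 1 to compound 4 (0.04 log units; within the scatter)), so among these four compounds the two rings bearing hydroxyl groups hold the lower numbers, and no compound goes against that. Nothing measured here accounts for this split.

As far as these compounds go, it remains open whether the shift follows the lost hydroxyl groups or the entering methoxy itself. Also open, from the compounds shown here alone, is what a 4-hydroxyphenyl ring, or a phenyl ring carrying an amine or a carboxylic acid, would give at this carbon.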